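The source may report more compounds than this note shows. Statements on the series, on what has been measured and on what is new or still open speak of the compounds shown alone.

The measured compounds, each with its number in a functional assay on MCF7 cells (Homo sapiens) for inhibition, read by MTT assay, with a stated time of 72 h; on this read-out lower numbers stand for stronger inhibition of growth and higher numbers for weaker inhibition of growth:

Compound 1 `O=S(=O)(NCCCNCc1ccccc1)c1cc(C(F)(F)F)cc(C(F)(F)F)c1` gives 3000 nM.
Compound 2 `O=S(=O)(NCCCNCc1cccc2ccccc12)c1cc(C(F)(F)F)cc(C(F)(F)F)c1` gives 1400 nM.
Compound 3 `COc1ccc(CNCCCNS(=O)(=O)c2cc(C(F)(F)F)cc(C(F)(F)F)c2)cc1` gives 2500 nM.

Compound 3 stands second highest of these three numbers; its nearest neighbour is compound 1, a gap within the scatter, and its furthest is compound 2, with a 1.8-fold higher number from compound 2 to compound 3 (0.25 log units; within the scatter) also within the scatter. Compound 4 `O=S(=O)(NCCCNCc1ccc(Cl)cc1)c1cc(C(F)(F)F)cc(C(F)(F)F)c1` differs from compound 3 by chloro in place of methoxy on an aromatic carbon. Going by the values given here, no measured step swaps these two groups directly. Among the compounds with values here, the step of a 1.2-fold lower number from compound 1 to compound 3 (0.08 log units; within the scatter) shows that placing the methoxy changed the number only within the scatter, and the one step beyond the scatter, a 2.1-fold lower number from compound 1 to compound 2 (0.33 log units; beyond the scatter), concerns a different part of the molecule. For compound 4 the step of no change at the digits printed from compound 3 to compound 4 (within the scatter) is therefore expected to stay within the scatter. Compound 4 is estimated at 2500 nM, between 1200 nM and 5000 nM.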

Compound 4, concentration for 50% growth inhibition: 2400 nM
The estimate for compound 4 lay 1.0-fold (0.02 log units) above the measured number; low and high end bracket the measured number.
By their numbers in this assay, from the lowest: compounds 2, 4, 3 and 1 (each within the scatter of the next, the first and the last beyond it).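

In this assay, chloro in place of methoxy on this aromatic carbon, para to a large group, gives a 1.0-fold lower number from compound 3 to compound 4 (0.02 log units; within the scatter), and chloro in place of hydrogen gives a 1.3-fold lower number from compound 1 to compound 4 (0.10 log units; within the scatter), so hydrogen, methoxy and chloro here all read alike within the scatter. The step to the 4-chlorophenyl group from naphthalen-1-yl, a 1.7-fold higher number from compound 2 to compound 4 (0.23 log units; within the scatter), also stays within the scatter. Nothing available gives a reason for this sameness.

On these data alone, whether an amine or a carboxylic acid on this aromatic carbon would move the number beyond the scatter remains open, as does the outcome of a longer chain in the shared core.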